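Carbamate to Amide: What to Expect for Compound 4

A few compounds are considered here, and "the series" means these few. Any claim that something is new, unique, unknown or untested is made for them only; others in the source may bear on it.

Of the compounds shown here, three built on one shared core have been measured in an ADME assay on microsomes from liver (Mus musculus) for metabolic stability, read by LC-MS, using NADPH, tested at 1 uM; on this read-out higher numbers stand for a longer-lived compound and lower numbers for a shorter-lived compound. Compound 1 `COC(=O)NS(=O)(=O)c1sc(CC(C)C)cc1-c1cccc(Cn2ccnc2)c1` gives 3.67 h. Compound 2 `CCCCCOC(=O)NS(=O)(=O)c1sc(CC(C)C)cc1-c1cccc(Cn2ccnc2)c1` gives 0.283 h, and compound 3 `CCCC(=O)NS(=O)(=O)c1sc(CC(C)C)cc1-c1cccc(Cn2ccnc2)c1` gives 0.115 h. Compound 2 therefore stands second of the three: the step of a 13-fold lower number from compound 1 to compound 2 (1.11 log units; beyond the scatter) lies above it, and the step of a 2.5-fold lower number from compound 2 to compound 3 (0.39 log units; beyond the scatter) lies below it, while the step of a 32-fold lower number from compound 1 to compound 3 (1.50 log units; beyond the scatter) spans the whole spread.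

Compound 4 `CCCCCC(=O)NS(=O)(=O)c1sc(CC(C)C)cc1-c1cccc(Cn2ccnc2)c1` has not yet been measured. It differs from compound 2 by pentyl in place of pentyloxy on a carbonyl carbon. Within the data shown here, the nearest precedent is the step of a 2.5-fold lower number from compound 2 to compound 3 (0.39 log units; beyond the scatter), in which pentyloxy on a carbonyl carbon gave way to propyl; the step of a 32-fold lower number from compound 1 to compound 3 (1.50 log units; beyond the scatter) runs in the same direction and was larger. The analyst therefore expects a modest drop in this assay from compound 2 to compound 4, a 2.4-fold lower number from compound 2 to compound 4 (0.37 log units; beyond the scatter). For compound 4 the analyst estimates 0.12 h, with a range from 0.05 h to 0.3 h.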

Compound 4, half-life: 0.148 h
Estimate against measurement, compound 4: 1.2-fold (0.09 log units) below; low and high end bracket the measured number.
By their numbers in this assay, from the lowest: compounds 3, 4 and 2 (each within the scatter of the next, the first and the last beyond it); then compound 1.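

In this assay, the exchange of pentyloxy for pentyl on the carbonyl carbon gives a 1.9-fold lower number from compound 2 to compound 4 (0.28 log units; within the scatter), so with this chain the oxygen link makes no difference that can be told from the scatter. Extending the chain on the amide side gives a 1.3-fold higher number from compound 3 to compound 4 (0.11 log units; within the scatter), so propyl and pentyl cannot be told apart at this position either. Among these compounds, the methoxy of compound 1 remains the one group here that stands well apart, with a 25-fold lower number from compound 1 to compound 4 (1.39 log units; beyond the scatter).

Nothing available here explains why these numbers fall as they do. Going by these compounds, it remains open whether methyl on the carbonyl carbon or ethoxy in place of methoxy would keep the long half-life of compound 1, and so whether the short chain or the oxygen link matters more.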